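Replacing phenyl with 1,3-thiazol-2-yl on the amide nitrogen

A few compounds are considered here, and "the series" means these few. Any claim that something is new, unique, unknown or untested is made for them only; others in the source may bear on it.

Three amides sharing one core have been tested in a functional assay on HCT-116 cells (Homo sapiens) for antiproliferative activity, read by MTT assay, with a stated time of 72 h; on this read-out higher numbers stand for weaker inhibition and lower numbers for stronger inhibition. Compound 1 `CCNC(=O)CCc1cccc2c1B(O)OC2` gives > 100000 nM, which is a limit of the assay and not a number. Compound 2 `CC(C)(C)NC(=O)CCc1cccc2c1B(O)OC2` gives > 100000 nM, again a limit. Compound 3 `O=C(CCc1cccc2c1B(O)OC2)Nc1ccccc1`, at 350 nM, is the only one of the three with an actual number. The steps to it are large and beyond the scatter: an at least 280-fold lower number from compound 1 to compound 3 (2.45 log units; beyond the scatter), and an at least 280-fold lower number from compound 2 to compound 3 (2.45 log units; beyond the scatter).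

Compound 4 `O=C(CCc1cccc2c1B(O)OC2)Nc1nccs1` changes only the group on the amide-type nitrogen: 1,3-thiazol-2-yl in place of phenyl on an amide-type nitrogen. For the measured compounds named here, no measured step swaps one aromatic ring for another, so the evidence is indirect. Phenyl in place of ethyl gave an at least 280-fold lower number from compound 1 to compound 3 (2.45 log units; beyond the scatter), and compound 4 still carries an aromatic ring at that place, so it should keep most of that gain. The expected change is a modest rise in the number, meaning somewhat weaker inhibition, estimated as a 2.9-fold higher number from compound 3 to compound 4 (0.46 log units; beyond the scatter). For compound 4 the estimated value is 1000 nM, with an expected range of 150 nM to 8000 nM.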

Compound 4, half-maximal inhibitory concentration: > 100000 nM
Compound 4: a limit, no number; the forecaster's own chance of this, stated with the estimate: 10%; at least 100-fold (2.00 log units) between middle value and limit.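

In this assay, the change from phenyl to 1,3-thiazol-2-yl gives an at least 280-fold higher number from compound 3 to compound 4 (2.45 log units; beyond the scatter), so an aromatic ring on the amide-type nitrogen is not enough on its own to keep a measurable value. Compound 4 gives > 100000 nM, which is a limit of the assay and not a number. The steps from compound 1 and from compound 2 to compound 4 cannot be read, and only compound 3 stands apart from the limit shared by the others: the limit of > 100000 nM in this assay, at which 3 of the 4 values shown sit.

The compounds shown do not tell which difference between the two rings matters, or whether any group other than plain phenyl can give a measurable value here. A phenyl ring carrying a chlorine or a methoxy group, or a benzyl group on the same nitrogen, would begin to answer that.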